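This account rests on a few compounds, and the source may have more. Where it says the series, first, only, none or still open, it means among the compounds named here.

Of the two numbers recorded in a functional assay on HepG2 cells (Homo sapiens) for cytotoxicity, read by MTT assay, with a stated time of 72 h (a higher number here means a weaker inhibitor, a lower number a stronger inhibitor), compound 1, `COc1ccc2ccc(=O)oc2c1C(/C=C/c1ccccc1)=N/NC(N)=O`, holds the higher one, with compound 1 giving 82 nM. Its neighbour, compound 2, `COc1ccc2ccc(=O)oc2c1C1=NN(C(C)=O)C(c2ccc(SC)cc2)C1`, gives 42 nM in this assay, and that gap lies within the scatter, so the two compounds cannot be told apart on these data. Compound 3, `COc1ccc2ccc(=O)oc2c1C(/C=C/c1cccs1)=N/NC(N)=O`, awaits measurement; it differs from compound 1 by thiophen-2-yl in place of phenyl on a double-bonded chain carbon bound to a double-bonded chain carbon. Among the measured compounds shown here, no measured step of this kind is available to guide the expectation, so the step expected in this assay is a 1.0-fold lower number from compound 1 to compound 3 (0.01 log units; within the scatter), nothing beyond the scatter. Compound 3 is therefore estimated at 80 nM, with a likely range from 35 nM to 180 nM.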

Compound 3, half-maximal inhibitory concentration: 75 nM
Compound 3: the middle estimate sits 1.1-fold (0.03 log units) above what was measured; low and high end bracket the measured number.
By their numbers in this assay, from the lowest: compounds 2, 3 and 1 (each within the scatter of the next).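

In this assay, among the compounds shown here, the replacement of phenyl by thiophen-2-yl gives a 1.1-fold lower number from compound 1 to compound 3 (0.04 log units; within the scatter) and so provides the first reading at this position: 2-(thiophen-2-yl)ethenyl stands in for 2-phenylethenyl with no difference these data can detect. For this one replacement, the aromatic ring on the chain need not be six-membered or made of carbon only. No measurement given here accounts for this result. On these data alone, whether an amine or a carboxylic acid on that ring would shift the number stays open. So does the effect of a longer chain.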